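Hydroxy for Sulfanyl: From Compound 2 to Compound 3

This account rests on a few compounds, and the source may have more. Where it says the series, first, only, none or still open, it means among the compounds named here.

Two measured compounds frame this account. Compound 1 `CC(C)c1ncn2c(O)nncc12` and compound 2 `CCc1ncn2c(S)nncc12` were both tested in a functional assay for inhibition, with Homo sapiens as the target; a higher number here means a weaker inhibitor, a lower number a stronger inhibitor. For compound 1 the outcome in this assay is a limit of the assay, > 48000 nM. For compound 2 the outcome in this assay is likewise a limit of the assay, > 48000 nM. Compound 2 therefore stands at the limit of > 48000 nM in this assay, at which 2 of the 2 values shown sit. Compound 3 `CCc1ncn2c(O)nncc12` arises from compound 2 by hydroxy in place of sulfanyl on an aromatic carbon. For the measured compounds named here, no step between measured compounds is available here, so no measured direction can be read from them. On that ground the step expected from compound 2 to compound 3 is a step that the limit leaves unreadable from compound 2 to compound 3, none beyond the scatter. Compound 3 is accordingly estimated at 60000 nM, with a range from 30000 nM to 200000 nM, and the assay is expected most likely to report only a limit once more.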

Compound 3, half-maximal inhibitory concentration: > 48000 nM
Compound 3 gave a limit, no number (the forecaster's own chance of this, stated with the estimate: 85%); the middle value lies beyond the limit too.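

No step among compound 1, compound 2 and compound 3 can be read in this assay, as all three results are limits: the limit of > 48000 nM in this assay, at which 3 of the 3 values shown sit.

The compounds shown leave open whether hydroxy and sulfanyl differ at all in this assay, and whether any change to the shared core would yield a number.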